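The source may hold more compounds than are shown below. What is called first, only, known or untested is meant among the compounds shown, and "the series" means these compounds.

Compound 3 `CNC(=O)c1cc(Oc2ccc3nc(NC(=O)c4cc(Cl)cc(Cl)c4)sc3c2)ccn1` gives 84.3% in a functional assay on SK-BR-3 cells (Homo sapiens) for inhibition, read by MTT assay, with a stated time of 2 days, tested at 100 uM (a higher number here means more inhibition of growth at the concentration tested, a lower number less inhibition of growth), the second highest of three numbers. Compound 2 `CNC(=O)c1cc(Oc2ccc3nc(NC(=O)Nc4ccc(N5CCN(C)CC5)cc4)sc3c2)ccn1` gives 86.4% and compound 1 `CNC(=O)c1cc(Oc2ccc3nc(NC(=O)c4ccc(Cl)cc4Cl)sc3c2)ccn1` gives 81%; both values lie within the scatter of compound 3. For the measured compounds named here, the only measured step, a number 3.3 percentage points higher from compound 1 to compound 3 (within the scatter), moves the chlorines on the same aryl group and stays within the scatter. Compound 4 `CNC(=O)c1cc(Oc2ccc3nc(NC(=O)Nc4ccc(Br)cc4)sc3c2)ccn1` differs from compound 3 by (4-bromophenyl)amino in place of 3,5-dichlorophenyl on a carbonyl carbon. This bears on compound 2, which already carries an aryl amino group on that carbonyl carbon; its value 86.4% sits within the scatter of compound 3. The expected step is therefore a number 1.3 percentage points lower from compound 3 to compound 4 (within the scatter), nothing beyond the scatter. Compound 4 is estimated at 83%, with a range from 70% to 93%.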

Compound 4, percent growth inhibition at one concentration: 69.2%
For compound 4 the middle estimate is 13.8 percentage points above the measured one; the measured number lies below the stated range.
By their numbers in this assay, from the lowest: compound 4; then compounds 1, 3 and 2 (each within the scatter of the next).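

On the carbonyl carbon, (4-bromophenyl)amino in place of 3,5-dichlorophenyl gives a number 15.1 percentage points lower from compound 3 to compound 4 (beyond the scatter), and in place of 2,4-dichlorophenyl it gives a number 11.8 percentage points lower from compound 1 to compound 4 (beyond the scatter), so an aryl amino group at this place does not by itself hold the level of compound 2. With that link kept, bromo in place of 4-methylpiperazin-1-yl on an aromatic carbon gives a number 17.2 percentage points lower from compound 2 to compound 4 (beyond the scatter) in this assay, which shows that the group on that aromatic carbon counts too. Nothing measured here explains these steps. As far as these compounds go, whether a morpholine or a dimethylamino group on that aromatic carbon would read like 4-methylpiperazin-1-yl or like bromo stays open.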